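A Nitro Group Enters the Benzoyl Ring of Compound 2

The compounds below may be only part of what the source reports. "The series", "measured", "known", "first", "only" and "open" are said of these compounds alone.

Of the compounds shown here, three built on one shared core have been measured in a functional assay on CCRF-CEM cells (Homo sapiens) for cytotoxicity, read by MTT assay, with a stated time of 96 h; a lower number here means that less compound is needed, a higher number that more compound is needed for the effect. Compound 1 `O=C(/C(=C\c1c(-c2ccccc2)[nH]c2ccccc12)C(=O)C(F)(F)F)c1ccco1` gives 1900 nM, compound 3 `N#C/C(=C\c1c(-c2ccccc2)[nH]c2ccccc12)C(=O)c1cccs1` gives 1200 nM, and compound 2 `CCOC(=O)/C(=C/c1c(-c2ccccc2)[nH]c2ccccc12)C(=O)c1ccccc1` gives 8000 nM. Compound 2 therefore stands highest of the three numbers: its value lies above that of compound 1 by a margin beyond the scatter, and further still above that of compound 3. Among the measured compounds shown here, the three compounds differ from one another at several places at once, so no single step between measured compounds can be read from them.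

Compound 4 `CCOC(=O)/C(=C/c1c(-c2ccccc2)[nH]c2ccccc12)C(=O)c1ccc([N+](=O)[O-])cc1` differs from compound 2 in one place: nitro in place of hydrogen on an aromatic carbon. The rest of the molecule, the core, the ester and the carbonyl arm, is kept. For the measured compounds named here, no measured pair shows what such a change does on this core, so the expectation rests on the position of compound 2 alone. The step expected in this assay is a 1.3-fold lower number from compound 2 to compound 4 (0.12 log units; within the scatter), which may well turn out to be none beyond the scatter. Compound 4 is estimated at 6000 nM, with a range from 2000 nM to 18000 nM.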

Compound 4, half-maximal effective concentration: 1800 nM
Compound 4: the middle estimate sits 3.3-fold (0.52 log units) above what was measured; the whole stated range lies above it.
By their numbers in this assay, from the lowest: compounds 3, 4 and 1 (each within the scatter of the next); then compound 2.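

In this assay, nitro in place of hydrogen on an aromatic carbon of the benzoyl ring of compound 2 brings a 4.4-fold lower number from compound 2 to compound 4 (0.65 log units; beyond the scatter) and so shows that this carbon, para to a large group, is a place where one change can move the number beyond the scatter. Among the compounds shown here, this is the only step on the shared core that can be read at a single place, which means that the finding rests on this one pair and shows no trend. Nothing measured here accounts for the lower number, so the compounds shown offer no explanation for the step.

Going by these compounds, it remains open whether the step belongs to nitro in particular or whether another group on the same carbon, such as an amine, a carboxylic acid or a methoxy group, would lower the number as well, or leave it unchanged or raise it. Also open, on these data alone, is whether nitro would give a similar step on another carbon of this ring, or with a nitrile in place of the ethyl ester.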